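Shortening the chain of compound 3

The compounds below may be only part of what the source reports. "The series", "measured", "known", "first", "only" and "open" are said of these compounds alone.

For the measured compounds named here, compound 3 `Nc1ncnc2c1c(-c1cnc3[nH]ccc3c1)nn2CCCCCCCCC(=O)NO` gives 12300 nM in a functional assay on A549 cells (Homo sapiens) for inhibition, read by MTT assay, with a stated time of 72 h (a lower number here means a stronger inhibitor, a higher number a weaker inhibitor), and holds the lowest number so far. Compound 1 `CNC(=O)CCCCCCCn1nc(-c2cnc3[nH]ccc3c2)c2c(N)ncnc21` gives 51000 nM in this assay as well. Compound 2 `Nc1ncnc2c1c(-c1cnc3[nH]ccc3c1)nn2CC(=O)NO` carries (hydroxycarbamoyl)methyl and reads > 150000 nM as a limit of the assay. Compound 4 `Nc1ncnc2c1c(-c1cnc3[nH]ccc3c1)nn2CCCCC(=O)NO` has hydroxycarbamoyl in place of 4-(hydroxycarbamoyl)butyl on a saturated chain carbon, four bonds along the chain from an aromatic nitrogen. Going by the values given here, two measured steps bear on this change: a 4.1-fold lower number from compound 1 to compound 3 (0.62 log units; beyond the scatter) is modest and an at least 2.9-fold higher number from compound 1 to compound 2 (0.46 log units; beyond the scatter) is at least modest, and they point in opposite directions. On that basis a modest rise is expected, with a 3.3-fold higher number from compound 3 to compound 4 (0.51 log units; beyond the scatter) as the estimated step in this assay for this shorter chain. The estimate for compound 4 is 40000 nM within an expected range (15000 nM to 120000 nM).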

Compound 4, half-maximal inhibitory concentration: > 150000 nM
Compound 4 ended at the assay's limit (the forecaster's own chance of this, stated with the estimate: 15%); at least 3.7-fold (0.57 log units) between middle value and limit.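

Keeping the hydroxycarbamoyl end and only shortening the chain gives an at least 12-fold higher number from compound 3 to compound 4 (1.08 log units; beyond the scatter), so chain length alone moves the number strongly in this assay. Compound 4 also falls behind compound 1, which ends in methylcarbamoyl, with an at least 2.9-fold higher number from compound 1 to compound 4 (0.46 log units; beyond the scatter). Compound 4 reads only as a limit of the assay, as does compound 2, and the step between them cannot be read: the limit of > 150000 nM in this assay, at which 2 of the 4 values shown sit.

Still open, as far as these compounds go, is where, among chain lengths from compound 4 to compound 3, the number starts to rise, and whether a longer chain lowers it further. A carboxylic acid in place of the hydroxycarbamoyl end of compound 3 is also untested here.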